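This account rests on a few compounds, and the source may have more. Where it says the series, first, only, none or still open, it means among the compounds named here.

Compound 1 `O=Cc1cc(=O)[nH]c(=O)n1[C@@H]1O[C@H](CO)[C@@H](O)[C@H]1O` | > 50000 nM
Compound 2 `Nc1c(F)c(=O)[nH]c(=O)n1[C@@H]1O[C@H](CO)[C@@H](O)[C@H]1O` | 600 nM

For the measured compounds named here, in a functional assay on SKW3 cells (Homo sapiens) for antiproliferative activity, read by WST assay, with a stated time of 3 days (a lower number here means a stronger inhibitor, a higher number a weaker inhibitor), compound 2 gives 600 nM as the only full number so far. Compound 1 gives > 50000 nM in this assay as a limit, not a number. Compound 3 `O=Cc1c(F)c(=O)[nH]c(=O)n1[C@@H]1O[C@H](CO)[C@@H](O)[C@H]1O` has formyl in place of amino on an aromatic carbon, ortho to a fluoro group (formyl in place of amino on an aromatic carbon). Compound 1 also carries formyl, and its > 50000 nM is the reason to look for weaker inhibition. A large step in that direction in this assay is expected, estimated as a 20-fold higher number from compound 2 to compound 3 (1.30 log units; beyond the scatter) here. Compound 3 is expected at 12000 nM (estimated range 2000 nM to 50000 nM).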

Compound 3, half-maximal inhibitory concentration: 300 nM
Beside the measured number, compound 3's estimate is 40-fold (1.60 log units) above it, outside the stated range (below it).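

On the aromatic carbon ortho to a fluoro group, formyl in place of amino gives a 2.0-fold lower number from compound 2 to compound 3 (0.30 log units; within the scatter) in this assay, so the two groups cannot be told apart here. With formyl held constant, fluoro in place of hydrogen gives an at least 160-fold lower number from compound 1 to compound 3 (2.22 log units; beyond the scatter), so formyl alone does not go with weak inhibition; the outcome depends on the fluoro group. Compound 1 is a limit, not a number: the limit of > 50000 nM in this assay, at which 1 of the 3 values shown sits.

Still open, as far as these compounds go, is whether a carboxylic acid or a nitrile at this position would read like formyl and amino. Also open, from the compounds shown here alone, is whether chlorine in place of fluoro would serve formyl equally.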